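The compounds below may be only part of what the source reports. "The series", "measured", "known", "first", "only" and "open" are said of these compounds alone.

Of the compounds shown here, two with a long branched side chain have been measured so far. In a functional assay on IMR-32 cells (Homo sapiens) for inhibition, with a stated time of 48 h, tested at 50 uM (a higher number here means more inhibition of growth at the concentration tested, a lower number less inhibition of growth), compound 1 `C=C[C@@](C)(/C=C/c1ccc(OC(=O)CCCCCCC)cc1)CCC=C(C)C` gives 51%, and compound 2 `CC[C@](C)(CCCC(C)C)CCc1ccc(O)c(I)c1` gives 21%. Compound 2 therefore holds the lower of the two numbers, and its gap to compound 1 lies beyond the scatter of repeated measurements.

The next compound, compound 3 `CC[C@](C)(CCCC(C)C)CCc1ccc(O)cc1`, differs from compound 2 in a single place: hydrogen in place of iodo on an aromatic carbon. In words, hydrogen stands in place of iodo on an aromatic carbon, ortho to a hydroxy group.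

Among the measured compounds shown here, no measured pair shows what this swap does on its own. Compound 1 differs from compound 2 in more than one place, so its value cannot isolate the iodo group. For the measured compounds named here, the expectation therefore stays close to compound 2 and its 21%, leaning slightly upward towards the only other number available. The expected change is a number 7 percentage points higher from compound 2 to compound 3 (within the scatter), a small rise within the scatter. For compound 3 the estimated value in this assay is 28%, with an expected range from 12% to 50%.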

Compound 3, percent growth inhibition at one concentration: 53%
Compound 3: middle estimate off by 25 percentage points, on the low side; the measured number lies above the stated range.
By their numbers in this assay, from the lowest: compound 2; then compounds 1 and 3 (each within the scatter of the next).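

In this assay, among the compounds shown here, the single exchange of hydrogen for iodo gives a number 32 percentage points higher from compound 2 to compound 3 (beyond the scatter), so this aromatic carbon, ortho to a hydroxy group, clearly matters for growth inhibition at the concentration tested. The side chain and the rest of the core are the same in both compounds, which places the whole of this step at that one atom and shows that the iodo group goes with the lower number here. For the compounds shown here, compound 1 differs from compound 2 in more than one place, so only this new pair isolates the iodo group, and nothing measured so far explains the size of the step.

On these data alone, it remains open whether the lower number is particular to iodo or would also appear with other groups on this carbon, such as chloro, methyl or an amine. As far as these compounds go, it is equally open how much the hydroxy group itself contributes, which a methoxy group in its place would help to show, and how these compounds would compare across a range of concentrations rather than at a single one.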